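Ester to Cyclopropyl Amide on a Pyridine Cinnamoyl Series

This account rests on a few compounds, and the source may have more. Where it says the series, first, only, none or still open, it means among the compounds named here.

Three compounds of this series carry a measured or attempted growth-inhibition read-out. For compound 1 `COC1CN(C(=O)/C=C/c2ccncc2-c2ccc(F)cc2)C1` the entry in a functional assay on HCT-116 cells (Homo sapiens) for inhibition, read by MTT assay, with a stated time of 72 h (a higher number here means a weaker inhibitor of growth, a lower number a stronger inhibitor of growth), reads "not determined" (no result reported). For compound 3 `CN1CCN(C(=O)/C=C/c2ccncc2-c2ccc(F)cc2)CC1` the entry in this assay likewise reads "not determined" (no result reported). Within the data shown here, compound 2 `CCOC(=O)/C=C/c1ccncc1-c1ccc2ccccc2c1` is therefore the only compound with a result: in this assay compound 2 gives 910 nM, and with nothing else to compare against, it stands alone.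

Compound 4 `O=C(/C=C/c1ccncc1-c1ccc2ccccc2c1)NC1CC1` differs from compound 2 in one place: cyclopropylamino in place of ethoxy on a carbonyl carbon. Among the measured compounds shown here, no pair of measured compounds shows how such a change shifts this read-out, so the expected step is the author's estimate only. Compound 4 is expected to lie close to compound 2, with the estimated step from compound 2 to compound 4 being a 1.3-fold lower number from compound 2 to compound 4 (0.11 log units; within the scatter), not clearly beyond the scatter. Compound 4 is estimated at 700 nM, within a range from 200 nM to 2500 nM.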

Compound 4, concentration for 50% growth inhibition: 6180 nM
Compound 4: the middle estimate sits 8.8-fold (0.95 log units) below what was measured; the measured number lies above the stated range.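

In this assay, cyclopropylamino in place of ethoxy on a carbonyl carbon gives a 6.8-fold higher number from compound 2 to compound 4 (0.83 log units; beyond the scatter) and weakens growth inhibition beyond the scatter. This first measured step shows that the read-out is sensitive to the group on this carbonyl carbon. Among these compounds, the single pair cannot separate the contribution of the three-membered ring from that of the amide hydrogen. How methylamino or a carboxylic acid at this carbonyl carbon would read remains open, and no measurement shown accounts for the shift.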